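Halogen swap on the anilino ring: compound 3 to compound 4

This account rests on a few compounds, and the source may have more. Where it says the series, first, only, none or still open, it means among the compounds named here.

Working notes on the series. All compounds share one core, a phenylsulfonyl-bearing bicycle with an anilino group; they differ only in the substituent on that anilino ring. Compound 1 `COc1cc(Nc2nc3ccccc3nc2S(=O)(=O)c2ccccc2)cc(OC)c1` is recorded in a functional assay on KB cells (Homo sapiens) for cytotoxicity, read by MTT assay, with a stated time of 72 h (a lower number here means a stronger inhibitor, a higher number a weaker inhibitor), as "not determined" (no result reported). Compound 2 `Nc1ccc(Nc2nc3ccccc3nc2S(=O)(=O)c2ccccc2)cc1` gives 3400 nM in this assay. Compound 3 `O=S(=O)(c1ccccc1)c1nc2ccccc2nc1Nc1ccc(F)cc1` gives only a limit of the assay in this assay, > 50000 nM. On the numbers shown, compound 3 is therefore the one entry that sits at the limit of > 50000 nM in this assay, at which 1 of the 3 values shown sits, and compound 1 is the one entry without a number.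

For the measured compounds named here, the single step measured is an at least 14-fold higher number from compound 2 to compound 3 (1.16 log units; beyond the scatter), fluoro in place of amino.

Compound 4 `O=S(=O)(c1ccccc1)c1nc2ccccc2nc1Nc1ccc(Cl)cc1` differs from compound 3 by chloro in place of fluoro on an aromatic carbon. Going by the values given here, no measured step swaps one halogen for another; the only step that bears on this position, an at least 14-fold higher number from compound 2 to compound 3 (1.16 log units; beyond the scatter), was large and moved compound 3 to the limit. A swap of fluoro for chloro is expected to give no step beyond the scatter, an at least 1.2-fold lower number from compound 3 to compound 4 (0.09 log units; that floor lies within the scatter), and compound 4 is expected to give a further limit as often as a number. The estimate for compound 4 is 40000 nM, with a range from 10000 nM to 100000 nM.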

Compound 4, half-maximal inhibitory concentration: 41200 nM
Compound 4: the middle estimate sits 1.0-fold (0.01 log units) below what was measured; the measured number falls inside the stated range.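

In this assay compound 3 remains a limit of the assay, so the halogen swap at this place on the anilino ring can be read only as a floor: the limit of > 50000 nM in this assay, at which 1 of the 4 values shown sits.

Chloro in place of fluoro gives an at least 1.2-fold lower number from compound 3 to compound 4 (0.08 log units; that floor lies within the scatter), and that floor shows no difference between the two halogens that can be told from the scatter, although compound 4 gives the first actual number for a halogen at this position. Chloro in place of amino gives a 12-fold higher number from compound 2 to compound 4 (1.08 log units; beyond the scatter), which puts a measured size on the gap that the fluoro step an at least 14-fold higher number from compound 2 to compound 3 (1.16 log units; beyond the scatter) could only bound, and amino carries the lower number in both comparisons.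

The compounds shown leave open whether this lower number belongs to amino alone or extends to another group at the same place, such as a hydroxyl, a dimethylamino or an acetamide. From the compounds shown here alone, compound 1 has no result reported, so the shared core offers no reading of methoxy groups on the anilino ring, and a heavier halogen such as bromo also remains open.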